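This account rests on a few compounds, and the source may have more. Where it says the series, first, only, none or still open, it means among the compounds named here.

Compound 1 `CCN(CC)c1cc(C)c2cc(NC(=O)c3ccc(Cl)c(Cl)c3)ccc2n1`: > 50000 nM
Compound 2 `Cc1cc(N2CCCCC2)nc2ccc(NC(=O)c3ccc(Cl)c(Cl)c3)cc12`: 31100 nM
Compound 3 `Cc1cc(N2CCN(C(C)C)CC2)nc2ccc(NC(=O)c3ccc(Cl)c(Cl)c3)cc12`: 1710 nM

All three compounds were tested in a functional assay on MCF7 cells (Homo sapiens) for antiproliferative activity, read by MTT assay, with a stated time of 72 h; on this read-out higher numbers stand for weaker inhibition and lower numbers for stronger inhibition. The entry for compound 1, > 50000 nM, is a limit of the assay and not a number. Compound 3 is the most potent of the three, with 1710 nM. For the measured compounds named here, the only other true number belongs to compound 2, at 31100 nM.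

The next structure is compound 4 `Cc1cc(NCCN2CCCCC2)nc2ccc(NC(=O)c3ccc(Cl)c(Cl)c3)cc12`. It carries (2-(piperidin-1-yl)ethyl)amino in place of the 4-isopropylpiperazin-1-yl of compound 3, on an aromatic carbon next to the ring nitrogen: (2-(piperidin-1-yl)ethyl)amino in place of 4-isopropylpiperazin-1-yl on an aromatic carbon.

Measured changes at this same place show that it can matter a great deal. Two steps are large: an at least 29-fold lower number from compound 1 to compound 3 (1.46 log units; beyond the scatter) and an 18-fold lower number from compound 2 to compound 3 (1.26 log units; beyond the scatter). The third, an at least 1.6-fold lower number from compound 1 to compound 2 (0.20 log units; that floor lies within the scatter), is only a floor within the scatter. Going by the values given here, no measured compound carries the entering group, so these steps give no direction for the new change. The two groups hold the same atoms, joined differently, so no step beyond the scatter is expected in this assay. The expected step is a 1.1-fold lower number from compound 3 to compound 4 (0.06 log units; within the scatter). The size of an 18-fold lower number from compound 2 to compound 3 (1.26 log units; beyond the scatter) argues for a wide range in either direction. The estimated value for compound 4 is 1500 nM, with an expected range from 400 nM to 8000 nM.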

Compound 4, half-maximal inhibitory concentration: 1190 nM
Compound 4: middle estimate off by 1.3-fold (0.10 log units), on the high side; the range from low to high includes it.
By their numbers in this assay, from the lowest: compounds 4 and 3 (each within the scatter of the next); then compound 2. At a limit, above all of these: compound 1.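

In this assay, the step is a 1.4-fold lower number from compound 3 to compound 4 (0.16 log units; within the scatter), so rejoining the same atoms as an open (2-(piperidin-1-yl)ethyl)amino chain leaves the read-out within the scatter, even though the group now has a hydrogen-bond donor and its ring holds only one hetero atom. The low number of compound 3 is therefore not tied to the 4-isopropylpiperazin-1-yl ring, and the step of a 26-fold lower number from compound 2 to compound 4 (1.42 log units; beyond the scatter) shows that the same piperidine ring gives a much lower number when it sits on this chain than when it is bound directly to the aromatic carbon. The step of an at least 42-fold lower number from compound 1 to compound 4 (1.62 log units; beyond the scatter) points the same way but is only a floor, as compound 1 stands at a limit of the assay and not at a number: the limit of > 50000 nM in this assay, at which 1 of the 4 values shown sits.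

The compounds shown leave open whether the length of the chain matters, which a longer (3-(piperidin-1-yl)propyl)amino chain would test. They also leave open whether the second nitrogen of the group is needed, which a morpholin-4-yl ring, with an oxygen in that place, would help to settle.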